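Working notes on compound 4 in the cytotoxicity series

This account rests on a few compounds, and the source may have more. Where it says the series, first, only, none or still open, it means among the compounds named here.

Compound 1 `COc1ccc([C@H]2CC(=O)N(c3cccc(N(C)C)c3)C2)cc1OC1CCCC1` is the reference point. In a functional assay on HEK293 cells (Homo sapiens) for cytotoxicity (on this read-out lower numbers stand for higher toxicity in this test and higher numbers for lower toxicity in this test), compound 1 gives > 10000 nM, which is a limit of the assay and not a number. Compound 2 `COc1ccc([C@H]2CC(=O)N(c3ccc(C)c(N)c3)C2)cc1OC1CCCC1` also gives only a limit in this assay, namely > 10000 nM. Compound 3 `COc1ccc([C@H]2CC(=O)N(c3cc(N)cc(F)c3)C2)cc1OC1CCCC1` gives only a limit in this assay as well, namely > 10000 nM. All three values therefore sit at the limit of > 10000 nM in this assay, at which 3 of the 3 values shown sit, and the steps a step that the two limits leave unreadable from compound 1 to compound 2, a step that the two limits leave unreadable from compound 1 to compound 3 and a step that the two limits leave unreadable from compound 2 to compound 3 cannot be read in size or direction.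

Compound 4 `COc1ccc(S(=O)(=O)Nc2cccc(N3C[C@@H](c4ccc(OC)c(OC5CCCC5)c4)CC3=O)c2)cc1` is still to be measured in this assay. It differs from compound 1 as follows: ((4-methoxyphenyl)sulfonyl)amino in place of dimethylamino on an aromatic carbon. This change is of a different kind from the measured ones, which all exchanged one substituted phenyl for another on the amide-type nitrogen in a ring, and none of those steps was readable. No direction can be drawn from them, so the working expectation is simply that compound 4 stays without measurable toxicity in the tested range, and the step that the limit leaves unreadable from compound 1 to compound 4 is expected to stay within the scatter. Compound 4 is estimated at 15000 nM, in the range 5000 nM to 50000 nM, most likely reported again only as a limit.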

Compound 4, half-maximal cytotoxic concentration: > 10000 nM
Compound 4: no number, only a limit (the forecaster's own chance of this, stated with the estimate: 75%); the middle value lies beyond the limit too.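

In this assay compound 4 gives > 10000 nM, which is a limit of the assay and not a number. The change from compound 1 to compound 4 therefore gives no readable step, and all the compounds share one limit: the limit of > 10000 nM in this assay, at which 4 of the 4 values shown sit.

The compounds shown leave open at what concentration, if any, compound 1 or compound 4 becomes toxic to these cells.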